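Thiophene swap on a series held at its limit

This account rests on a few compounds, and the source may have more. Where it says the series, first, only, none or still open, it means among the compounds named here.

- compound 1 `COc1cccc(-c2nc3cccc(-c4cc(OC)c(OC)c(OC)c4)c3o2)c1`: > 25000 nM
- compound 2 `COc1cc(-c2cccc3nc(-c4ccc(C)cc4)oc23)cc(OC)c1OC`: > 25000 nM
- compound 3 `COc1cc(-c2cccc3nc(-c4ccc(N)cc4)oc23)cc(OC)c1OC`: > 25000 nM

All three entries come from a functional assay on MCF7 cells (Homo sapiens) for antiproliferative activity, read by MTT assay, with a stated time of 48 h (on this read-out higher numbers stand for weaker inhibition and lower numbers for stronger inhibition), and each is a limit, not a number. In this assay compound 3 gives > 25000 nM, which is a limit. The series offers no ranking, as every compound rests on (the limit of > 25000 nM in this assay, at which 3 of the 3 values shown sit).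

Compound 4 `COc1cc(-c2cccc3nc(-c4cccs4)oc23)cc(OC)c1OC` has thiophen-2-yl in place of 4-aminophenyl on an aromatic carbon, next to the ring nitrogen and next to the ring oxygen (thiophen-2-yl in place of 4-aminophenyl on an aromatic carbon).

Within the data shown here, three measured steps bear on this change: a step that the two limits leave unreadable from compound 1 to compound 2, a step that the two limits leave unreadable from compound 1 to compound 3 and a step that the two limits leave unreadable from compound 2 to compound 3. None of them has a readable size, so they give no measure or direction for the new change. The expectation in this assay therefore rests on the position of compound 3 at > 25000 nM, and the most likely outcome is another limit, or a number close to it. The estimated step is a step that the limit leaves unreadable from compound 3 to compound 4, and no firm direction is expected. For compound 4 the expected value is 30000 nM, with an estimated range of 12000 nM to 60000 nM.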

Compound 4, half-maximal inhibitory concentration: > 25000 nM
Compound 4 gave a limit, no number; the forecaster's own chance of this, stated with the estimate: 75%; the middle value does not contradict the limit.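

No new step can be read from compound 1, compound 2 or compound 3 to compound 4 in this assay, since all four compounds rest on a limit: the limit of > 25000 nM in this assay, at which 4 of the 4 values shown sit.

The compounds shown leave open whether any group at this place on the shared core gives a number rather than a limit in this assay, and how these groups would rank.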